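This account rests on a few compounds, and the source may have more. Where it says the series, first, only, none or still open, it means among the compounds named here.

Of the compounds shown here, three from one series have been tested in a functional assay on the whole organism (artery, strain albino) with Rattus norvegicus as the target, with a stated time of 300 min, at a dose of 10 mg/kg by the oral route; on this read-out lower numbers stand for less inhibition and higher numbers for more inhibition at the one dose given (going by the name of the read-out). Compound 1, `CC1=C(C(=O)Nc2ccc(Br)cc2)C(c2ccc(Cl)cc2Cl)N=C(SCc2ccccc2)N1`, gives 22.1% in this assay. Compound 2, `CC1=C(C(=O)Nc2ccc(Br)cc2)C(c2ccc(Cl)cc2Cl)N=C(SCc2ccc(Cl)cc2)N1`, gives 38.5% in this assay. The change that turns compound 1 into compound 2 is chloro in place of hydrogen on an aromatic carbon, and it made a step of a number 16.4 percentage points higher from compound 1 to compound 2 (beyond the scatter). Compound 3, `CC1=C(C(=O)Nc2ccc([N+](=O)[O-])cc2)C(c2cccc([N+](=O)[O-])c2)N=C(SCc2ccccc2)N1`, gives 25.6% in this assay; the difference between its core and the core of compound 1 is not broken down here.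

Compound 4, `CC1=C(C(=O)Nc2ccc([N+](=O)[O-])cc2)C(c2cccc([N+](=O)[O-])c2)N=C(SCc2ccccc2Cl)N1`, has not yet been measured. It differs from compound 3 by chloro in place of hydrogen on an aromatic carbon. Among the measured compounds shown here, this is the same kind of change as the one from compound 1 to compound 2, not the same: there the chlorine sits para to a large group, here it sits ortho to a large group, so the earlier step is only a rough guide. For the measured compounds named here, on that basis compound 4 is expected to show a step of a number 7.4 percentage points higher from compound 3 to compound 4 (within the scatter), a smaller step than the one seen between compound 1 and compound 2, because the value of compound 3 is 25.6% and the new chlorine sits in a different place. The estimate for compound 4 is therefore 33%, expected between 20% and 48%.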

Compound 4, a percentage reported as inhibition, in the whole organism at one dose (the size of the read-out at that dose, not a potency): 15.9%
Estimate against measurement, compound 4: 17.1 percentage points above, and the stated range ends above it.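

In this assay, adding a chlorine to the benzyl ring did not carry over in the same way from one core to the other: the same change on two cores in this assay, a number 16.4 percentage points higher (beyond the scatter) from compound 1 to compound 2 and a number 9.7 percentage points lower (within the scatter) from compound 3 to compound 4, 26.1 percentage points apart, beyond the scatter of two such steps

Taken alone, the step of a number 9.7 percentage points lower from compound 3 to compound 4 (within the scatter) does not show that chlorine lowers the number on this core, so the safe reading is only that the gain seen on the core of compound 1 cannot be assumed elsewhere. Among the compounds shown here, it also remains unsettled whether the core or the place of the chlorine matters: the new chlorine sits ortho to a large group, the one in compound 2 sits elsewhere on the ring, and the two steps differ in both at once.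

The compounds shown leave open how a 2-chlorobenzyl group would behave on the core of compound 1, and how a chlorine placed as in compound 2 would behave on the core of compound 3. They also leave open what a methoxy group or an amine on the benzyl ring would do, or a longer chain in place of the benzyl group.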